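The source may report more compounds than this note shows. Statements on the series, on what has been measured and on what is new or still open speak of the compounds shown alone.

Measured so far:
Compound 1 `CC(C)(C)C1=C(C(=O)O)N2C(=O)[C@H](CO)[C@H]2O1`: 5 h
Compound 2 `C[C@@H](O)[C@H]1C(=O)N2C(C(=O)O)=C(C(C)(C)C)O[C@H]12`: 8.1 h

In an ADME assay, in phosphate buffer, at 28 degrees C, at pH 7.0 (on this read-out lower numbers stand for a shorter-lived compound and higher numbers for a longer-lived compound), compound 2 and compound 1 sit close together: a 1.6-fold higher number from compound 1 to compound 2 (0.21 log units; within the scatter). That single step changed the same place that is changed now, putting in a methyl, and moved the number only within the scatter.

Compound 3 `COC(=O)[C@@H](O)[C@H]1C(=O)N2C(C(=O)O)=C(C(C)(C)C)O[C@H]12` differs from compound 2 by methoxycarbonyl in place of methyl on a saturated chain carbon bound to an oxygen on a saturated carbon and a saturated ring carbon. Going by the values given here, no measured step shows a methoxycarbonyl anywhere, so the only guide is that this place tolerated a change without a shift beyond the scatter. The step of a 1.4-fold lower number from compound 2 to compound 3 (0.13 log units; within the scatter) is therefore expected to stay within the scatter, in no clear direction. Compound 3 is estimated at 6 h, with a range from 3 h to 12 h.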

Compound 3, half-life: 6.2 h
Beside the measured number, compound 3's estimate is 1.0-fold (0.01 log units) below it, within the range that was stated.
By their numbers in this assay, from the lowest: compounds 1, 3 and 2 (each within the scatter of the next).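

In this assay this place on the saturated chain carbon accepts methoxycarbonyl, with 4 heavy atoms where methyl had 1, and the number stays within the scatter (a 1.3-fold lower number from compound 2 to compound 3 (0.12 log units; within the scatter)). Measured against hydrogen at the same place, the new group also stays within the scatter (a 1.2-fold higher number from compound 1 to compound 3 (0.09 log units; within the scatter)). No measurement here explains why this place responds so little.

Open, as far as these compounds go, is whether an amine, a carboxylic acid or a longer chain at this place would also stay within the scatter.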